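Working notes: aryl ester exchange and cytotoxicity read-out

A few compounds are considered here, and "the series" means these few. Any claim that something is new, unique, unknown or untested is made for them only; others in the source may bear on it.

Measured so far:
compound 1 `Clc1ccc2c(-n3cc(C4CCCCC4)nn3)ccnc2c1` — in an ADME assay on HepG2 cells (Homo sapiens) for cytotoxicity, read by MTT assay, with a stated time of 24 h (on this read-out higher numbers stand for lower toxicity in this test and lower numbers for higher toxicity in this test), compound 1 gives > 3200 nM.
compound 2 `CCc1ccccc1C(=O)OCc1cn(-c2ccnc3cc(Cl)ccc23)nn1` — in this assay compound 2 gives > 2550000 nM.

Neither value is a number; both are limits of the assay. For compound 1 the read-out stops at a limit, (the limit of > 3200 nM in this assay, at which 1 of the 2 values shown sits). For compound 2 the read-out likewise stops at a limit, (the limit of > 2550000 nM in this assay, at which 1 of the 2 values shown sits). For the measured compounds named here, compound 2 therefore stands nowhere on a scale of numbers: all that is known of it in this assay is that the reported value is a limit, and the same holds for the one other compound measured. Going by the values given here, no step between measured compounds that differ in a single place is available, so the series gives no measured size for any change.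

Compound 3 `O=C(OCc1cn(-c2ccnc3cc(Cl)ccc23)nn1)c1ccc(C(F)(F)F)cc1` differs from compound 2 in one place: 4-(trifluoromethyl)phenyl in place of 2-ethylphenyl on a carbonyl carbon. Among the compounds with values here, with no measured step to lean on, the step from compound 2 to compound 3 is expected to be none beyond the usual scatter, an at least 1.2-fold lower number from compound 2 to compound 3 (0.10 log units; that floor lies within the scatter). Compound 3 is estimated at 2000000 nM in this assay, with a range from 400000 nM to 6000000 nM, and a good chance that the assay again reports only a limit.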

Compound 3, half-maximal cytotoxic concentration: 1070000 nM
Beside the measured number, compound 3's estimate is 1.9-fold (0.27 log units) above it; measured number inside the range.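

In this assay the group on this carbonyl carbon makes a readable difference. 4-(trifluoromethyl)phenyl in place of 2-ethylphenyl gives an at least 2.3-fold lower number from compound 2 to compound 3 (0.37 log units; beyond the scatter), the first measured size for any change in the series, and the direction is towards higher toxicity in this test. The step is a floor and not a full size, since compound 2 stands only at a limit and not at a number: the limit of > 2550000 nM in this assay, at which 1 of the 3 values shown sits.

The change swaps two groups at once, so the compounds shown do not separate the loss of 2-ethylphenyl from the gain of 4-(trifluoromethyl)phenyl. Also open, from the compounds shown here alone, is where the read-out falls with plain phenyl on the same carbonyl carbon or with an aryl group carrying an amine or a carboxylic acid, and compound 1 cannot be tied to this step, as it differs from compound 2 and compound 3 in more than one place.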